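From Trifluoromethyl to Methyl on the Outer Ring

The source may report more compounds than this note shows. Statements on the series, on what has been measured and on what is new or still open speak of the compounds shown alone.

Of the compounds shown here, two have been measured so far. Going by the values given here, compound 1 `CC(C)(CC(N)=O)c1c(C#N)c(-c2ccc(Br)cc2)nc2cnccc12` and compound 2 `CC[C@@H](Nc1c(C#N)c(-c2ccc(-c3ccccc3C(F)(F)F)cc2)nc2cnccc12)C(N)=O` share a core but differ in more than one place, so no single step joins them, and only their two values can be set side by side. In a physicochemical assay for lipophilicity, read by HPLC, at pH 7.5 (a higher number here means a more lipophilic compound, a lower number a more polar compound), compound 1 gives 2.1. In this assay compound 2 gives 3.1, the highest of the two numbers, and its distance from compound 1 lies beyond the scatter of repeated measurements.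

Compound 3 `CC[C@@H](Nc1c(C#N)c(-c2ccc(-c3ccccc3C)cc2)nc2cnccc12)C(N)=O` is the next compound and differs from compound 2 in one place only. methyl in place of trifluoromethyl on an aromatic carbon Cut one bond further out, the difference reads 2-(trifluoromethyl)phenyl to 2-methylphenyl.

Among the compounds with values here, no measured step of this kind is at hand, so the expectation rests on the change alone. For compound 3 the step of a number 0.30 log units lower from compound 2 to compound 3 (within the scatter) in this assay is expected to be small and downward, at the edge of the scatter. Compound 3 is estimated to give 2.8 in this assay, with a range from 2.4 to 3.2.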

Compound 3, distribution coefficient: 3
Beside the measured number, compound 3's estimate is 0.20 log units below it, and the stated range covers the measured number.
By their numbers in this assay, from the lowest: compound 1; then compounds 3 and 2 (each within the scatter of the next).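

Exchanging trifluoromethyl for methyl, on an aromatic carbon of a six-membered aromatic ring of carbon only, gives a number 0.10 log units lower from compound 2 to compound 3 (within the scatter) in this assay, so at this position the two groups cannot be told apart by this measurement, although the heavy atoms go from 4 to 1. Going by these compounds alone, this is the first step that joins two compounds differing in one place, and it shows what the side-by-side values of the earlier compounds could not: what this one exchange does on its own, with the rest of the structure held constant. Nothing measured here bears on why the exchange leaves the number within the scatter.

The compounds shown leave open whether a carboxylic acid, an amine or a methoxy group at this same position would give a step beyond the scatter, or whether a plain hydrogen there would. They also leave open whether the exchange of trifluoromethyl for methyl would read the same on another carbon of this ring, since this single step speaks for one position only.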